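The source may hold more compounds than are shown below. What is called first, only, known or untested is meant among the compounds shown, and "the series" means these compounds.

Of the compounds shown here, three have been measured in a functional assay on U-87MG ATCC cells for antiproliferative activity against U-87 MG (Homo sapiens), read by MTT assay, with a stated time of 48 h, tested at 100 uM; a higher number here means a weaker effect of the compound at the concentration tested, a lower number a stronger effect. Compound 1 `Cc1nc(-c2ccc(Cl)cc2)sc1C(=O)CSc1nc(-c2ccc(Cl)c(Cl)c2)c(C#N)c(=O)[nH]1` gives 36.5% in this assay. Compound 2 `Cc1nc(-c2ccc(Cl)cc2)sc1C(=O)CSc1nc(-c2cccc(Cl)c2)c(C#N)c(=O)[nH]1` differs from compound 1 in a single place, (hydrogen in place of chloro on an aromatic carbon), and compound 2 gives 12.5%. Among the measured compounds shown here, that step, a number 24 percentage points lower from compound 1 to compound 2 (beyond the scatter), is the only one-place comparison among the measured compounds.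

Compound 3 `Cc1nc(-c2ccccc2)sc1C(=O)CSc1nc(N)c(C#N)c(-c2ccc(Cl)cc2)n1` is built on a different core; the difference between the two cores is not broken down here. In this assay compound 3 gives 17.1%, which sits within the scatter of the number for compound 2 and beyond the scatter below the number for compound 1.

Compound 4 `Cc1nc(-c2ccccc2)sc1C(=O)CSc1nc(N)c(C#N)c(-c2ccccc2)n1` has not yet been measured. Set against compound 3, the change is hydrogen in place of chloro on an aromatic carbon. For the measured compounds named here, this is the same kind of change as the one from compound 1 to compound 2, not the same change: in compound 1 the carbon that loses its chloro is ortho to a chloro group, whereas in compound 3 it is not, and the surrounding core differs as well. The earlier step lowered the number modestly. A smaller shift is expected here, because compound 3 already gives 17.1% and there is little room left to fall; the step is estimated at a number 5.1 percentage points lower from compound 3 to compound 4 (within the scatter). Compound 4 is therefore expected to give about 12%, most likely between 3% and 38%.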

Compound 4, a percentage reported as activity, at one concentration (the size of the read-out at that concentration, not a potency): 6.48%
Estimate against measurement, compound 4: 5.5 percentage points above; low and high end bracket the measured number.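

In this assay, putting hydrogen in place of chloro on an aromatic carbon, here the change from 4-chlorophenyl to phenyl, gives a number 10.6 percentage points lower from compound 3 to compound 4 (beyond the scatter), so a lower number, meaning a stronger effect at the concentration tested, now appears on a second core as well. Set side by side, the two steps run in the same direction and cannot be told apart in size: the same change on two cores in this assay, a number 24 percentage points lower (beyond the scatter) from compound 1 to compound 2 and a number 10.6 percentage points lower (beyond the scatter) from compound 3 to compound 4, 13.4 percentage points apart, within the scatter of two such steps. This shows that the change carried over from one core to the other in these two pairs, but it does not show that it would carry over to any further core, and it says nothing about why the number falls; each result is also a read-out at a single concentration, not a potency.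

The compounds shown leave open what a group other than chloro or hydrogen would do on these aromatic rings, such as a methoxy group, a fluoro group or a carboxylic acid. They also leave open whether the result would hold if the link joining the two parts of compound 4 were a longer chain, or if its amine were replaced by another group.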